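Replacing the acetyl on the chain of compound 3

The source may report more compounds than this note shows. Statements on the series, on what has been measured and on what is new or still open speak of the compounds shown alone.

Compound 3 `CC(=O)Cn1nc(-c2cccnc2)c2ccccc2c1=O` stands lowest of the three measured compounds in an assay on isolated protein (Oryctolagus cuniculus) with Thromboxane-A synthase (Homo sapiens) as the target, tested at 1 uM (on this read-out higher numbers stand for more inhibition at the one concentration tested (going by the name of the read-out) and lower numbers for less inhibition), giving 13%. Compound 1 `CCCn1nc(-c2cccnc2)c2ccccc2c1=O` gives 86%, and compound 2 `O=c1c2ccccc2c(-c2cccnc2)nn1Cc1cccc(Cl)c1` gives 95%; the steps of a number 73 percentage points lower from compound 1 to compound 3 (beyond the scatter) and a number 82 percentage points lower from compound 2 to compound 3 (beyond the scatter) both go with the acetyl entering at the same chain carbon. Compound 4 `O=c1c2ccccc2c(-c2cccnc2)nn1CCSc1nccs1` differs from compound 3 in one place: ((1,3-thiazol-2-yl)sulfanyl)methyl in place of acetyl on a saturated chain carbon bound to an aromatic nitrogen. An upward step in this assay is expected for compound 4 because a number 73 percentage points lower from compound 1 to compound 3 (beyond the scatter) and a number 82 percentage points lower from compound 2 to compound 3 (beyond the scatter) were both large and the acetyl now leaves in favour of a group carrying a five-membered aromatic ring. Compound 4 is expected to give 75%, ranging from 45% to 95%, an estimated step of a number 62 percentage points higher from compound 3 to compound 4 (beyond the scatter).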

Compound 4, a percentage reported as inhibition, at one concentration (the size of the read-out at that concentration, not a potency): 97%
Compound 4: the middle estimate sits 22 percentage points below what was measured; the measured number lies above the stated range.
By their numbers in this assay, from the lowest: compound 3; then compounds 1, 2 and 4 (each within the scatter of the next, the first and the last beyond it).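

In this assay, the step of a number 84 percentage points higher from compound 3 to compound 4 (beyond the scatter) shows that the acetyl's low number does not extend to every larger group at this saturated chain carbon bound to an aromatic nitrogen, and the step of a number 2 percentage points higher from compound 2 to compound 4 (within the scatter) puts the thiazole-bearing chain level with the 3-chlorophenyl. Within the data shown here, the step of a number 11 percentage points higher from compound 1 to compound 4 (beyond the scatter) is the first rise from compound 1 to lie beyond the scatter, with (1,3-thiazol-2-yl)sulfanyl in place of methyl. Nothing measured here accounts for these steps.

On these data alone, it stays open whether a chain ending in an amine or a carboxylic acid would behave like the acetyl or like the aromatic groups.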